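Chloro to methyl on a second core: expected solubility

The compounds below may be only part of what the source reports. "The series", "measured", "known", "first", "only" and "open" are said of these compounds alone.

The study concerns three measured compounds and one yet to be measured. Compound 1 `CC(C)(C)OC(=O)N1CCC(CCOC(=O)N2CCc3c2ccc(S(C)(=O)=O)c3Cl)CC1` and compound 2 `Cc1c(S(C)(=O)=O)ccc2c1CCN2C(=O)OCCC1CCN(C(=O)OC(C)(C)C)CC1` share one core; compound 3 `CC(C)(C)OC(=O)N1CCC(CCOC(=O)N2CCc3cc(S(C)(=O)=O)cc(Cl)c32)CC1` and compound 4 `Cc1cc(S(C)(=O)=O)cc2c1N(C(=O)OCCC1CCN(C(=O)OC(C)(C)C)CC1)CC2` share another. The difference between the two cores is not broken down here.

In a physicochemical assay for solubility, read by HPLC, at pH 6.8 (on this read-out higher numbers stand for higher solubility and lower numbers for lower solubility), compound 1 gives 0.21 ug/mL, and compound 2 gives 0.17 ug/mL. The change between them is methyl in place of chloro on an aromatic carbon, and it made a step of a 1.2-fold lower number from compound 1 to compound 2 (0.09 log units; within the scatter). Compound 3 gives 21 ug/mL in this assay, which is the highest of the three numbers: the gap to compound 1 and the gap to compound 2 both lie beyond the scatter.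

Compound 4 is the same kind of change applied to compound 3: methyl in place of chloro on an aromatic carbon. The place is not identical to that of the earlier change, which sat ortho to a methylsulfonyl group, while here the position is meta to a methylsulfonyl group and ortho to a fused ring. In this assay the step is expected to be a 1.2-fold lower number from compound 3 to compound 4 (0.09 log units; within the scatter), because the earlier step of a 1.2-fold lower number from compound 1 to compound 2 (0.09 log units; within the scatter) stayed within the scatter. Compound 4 is therefore estimated at 17 ug/mL, with a likely range from 6 ug/mL to 50 ug/mL.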

Compound 4, solubility: 44 ug/mL
The estimate for compound 4 lay 2.6-fold (0.41 log units) below the measured number, within the range that was stated.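

In this assay, methyl in place of chloro gave a 2.1-fold higher number from compound 3 to compound 4 (0.32 log units; beyond the scatter), whereas the same exchange on the other core had given a 1.2-fold lower number from compound 1 to compound 2 (0.09 log units; within the scatter), so the result on one core did not simply carry over to the other. This shows that the exchange can be tolerated on both cores without loss beyond the scatter, but with a single modest step on one core and a step within the scatter on the other, it establishes no rule for the series, and the chloro and methyl do not occupy an identical place on the two cores, so core and position cannot be separated here. No measurement offered here accounts for the difference between the two steps, and the reason for the modest rise remains unexplained.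

The compounds shown leave open how other groups on this aromatic carbon, meta to a methylsulfonyl group, such as a nitrile, a methoxy group or an amine, would read in this assay. They also leave open whether a carboxylic acid or a longer chain elsewhere on these molecules would change the size of the step from chloro to methyl.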